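The source may hold more compounds than are shown below. What is called first, only, known or untested is meant among the compounds shown, and "the series" means these compounds.

Going by the values given here, in an ADME assay on microsomes from liver (Rattus norvegicus) for metabolic stability, read by LC-MS, using NADPH, with a stated time of 10 min, tested at 0.5 uM (on this read-out lower numbers stand for a less stable compound and higher numbers for a more stable compound), compound 1 `CC(=O)Nc1cc(-c2ccc(OC[C@@H](N)CC(C)C)c(F)c2)ccn1` gives 80%, the lower of the two numbers measured so far, and compound 2 `CC(=O)Nc1cc(-c2ccc(OC[C@@H](N)CC(C)C)c(Cl)c2)ccn1` gives 100%. Compound 3 `CC(=O)Nc1cc(-c2cc(F)c(OC[C@@H](N)CC(C)C)cc2F)ccn1` differs from compound 1 as follows: fluoro in place of hydrogen on an aromatic carbon. Among the compounds with values here, the only measured step that bears on this, a number 20 percentage points higher from compound 1 to compound 2 (beyond the scatter), is modest and concerns chloro in place of fluoro on an aromatic carbon. Within the data shown here, no measured pair shows fluoro in place of hydrogen, so that step offers only a loose guide, and no change beyond the scatter is expected. The expected step is small: a number 2 percentage points higher from compound 1 to compound 3 (within the scatter). For compound 3 the estimated value is 82%, with an expected range from 65% to 98%.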

Compound 3, percent of the compound remaining: 90%
Beside the measured number, compound 3's estimate is 8 percentage points below it; measured number inside the range.
By their numbers in this assay, from the lowest: compounds 1, 3 and 2 (each within the scatter of the next, the first and the last beyond it).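

Fluoro in place of hydrogen on this aromatic carbon, ortho to a large group and para to a fluoro group, gives a number 10 percentage points higher from compound 1 to compound 3 (within the scatter) in this assay. The position therefore carries a second fluoro with no change beyond the scatter, whereas the earlier pair spoke only to chloro in place of fluoro at the other site. Nothing measured on these compounds gives a reason for this result. Going by these compounds, whether chloro or methoxy at this position would read like fluoro stays open, as does whether the added fluoro would behave the same alongside the chloro of compound 2.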